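The source may report more compounds than this note shows. Statements on the series, on what has been measured and on what is new or still open speak of the compounds shown alone.

Measured compounds in an ADME assay on HEK-293T cells (Homo sapiens) for cytotoxicity, read by CCK-8 assay, with a stated time of 48 h; a higher number here means that more compound is tolerated, a lower number that less compound is tolerated:
- compound 1 `Cn1cc(S(=O)(=O)CC(=O)Nc2ccc(Cl)cc2Cl)c2ccccc21`: > 100000 nM
- compound 2 `COc1ccc2[nH]cc(SCC(=O)Nc3ccc(Cl)c(Cl)c3)c2c1`: 61800 nM
- compound 3 `CCOc1ccccc1NC(=O)CSc1c[nH]c2c(Br)c(OC)ccc12`: > 100000 nM

In this assay compound 1 gives > 100000 nM, which is a limit of the assay and not a number. Compound 3 likewise returns a limit in this assay, > 100000 nM. Compound 2 is the only one of the three with a numeric value, 61800 nM in this assay. Compound 1 therefore stands at the limit of > 100000 nM in this assay, at which 2 of the 3 values shown sit; its own value and that of compound 3 are limits, so the gap to compound 2 cannot be sized. Among the compounds with values here, no pair of measured compounds differs in one place only, so the series gives no measured step from which the effect of a single change on this assay could be read.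

Compound 4 `Cn1cc(S(=O)(=O)CC(=O)Nc2cc(Cl)ccc2Cl)c2ccccc21` has not yet been measured in this assay. It differs from compound 1 as follows:
2,5-dichlorophenyl in place of 2,4-dichlorophenyl on an amide-type nitrogen
The two compounds contain the same atoms; only the dichlorophenyl pattern on the amide-type nitrogen is exchanged, 2,5-dichlorophenyl for 2,4-dichlorophenyl. Within the data shown here, with no measured step available, the expected step from compound 1 to compound 4 is none beyond the scatter, a number no higher from compound 1 to compound 4 (the limit leaves the size open). Compound 4 is therefore expected to give about 100000 nM in this assay, in a range from 40000 nM to 250000 nM, and most probably the assay will again report only a limit.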

Compound 4, half-maximal cytotoxic concentration: > 100000 nM
Compound 4 was reported as a limit; the forecaster's own chance of this, stated with the estimate: 75%; the middle value sits exactly at the limit.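

In this assay compound 4 gives > 100000 nM, a limit of the assay and not a number. Within the data shown here, compound 1 also returns only a limit, so no step between compound 1 and compound 4 can be read. The compounds shown leave open whether 2,5-dichlorophenyl in place of 2,4-dichlorophenyl on the amide-type nitrogen has any effect in this assay.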